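The source may hold more compounds than are shown below. What is called first, only, known or untested is meant among the compounds shown, and "the series" means these compounds.

Measured so far:

Compound 1, `CCC(CC)CNc1c(C(N)=O)cnc2ccc(C#N)cc12`, gives 74 uL/min in an ADME assay on cells (Hepatocyte, Rattus norvegicus) for metabolic stability, with a stated time of 90 min; a lower number here means slower removal, a higher number faster removal of the compound.
Compound 2, `C[C@@H](Nc1c(C(N)=O)cnc2ccc(C#N)cc12)c1ccc(Cl)cc1`, gives 41 uL/min in this assay.

Within the data shown here, of these two numbers, the one for compound 2 is the lower, but the gap to compound 1 is within the usual scatter of this assay, so the two compounds are not really told apart by these data. The next compound is compound 3, `C[C@@H](Nc1c(C(N)=O)cnc2ccc(-c3cccnc3)cc12)c1ccc(Cl)cc1`. Compared with compound 2 it carries one change: pyridin-3-yl in place of cyano on an aromatic carbon. Among the measured compounds shown here, no pair of measured compounds shows this same change, so there is nothing here that says how it shifts clearance in this assay. The expectation for compound 3 therefore rests only on the value of compound 2, with a wide range around it. The step from compound 2 to compound 3 is expected to be small, a 1.5-fold higher number from compound 2 to compound 3 (0.17 log units; within the scatter), tending toward a somewhat higher number, and may well stay within the scatter. For compound 3 the estimate in this assay is 60 uL/min, with a range from 25 uL/min to 150 uL/min.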

Compound 3, intrinsic clearance in a liver preparation (reported as CLH), per the amount of preparation that the assay uses: 70 uL/min
The estimate for compound 3 lay 1.2-fold (0.07 log units) below the measured number, and the stated range covers the measured number.
By their numbers in this assay, from the lowest: compounds 2, 3 and 1 (each within the scatter of the next).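

In this assay the swap at this aromatic carbon, pyridin-3-yl in place of cyano, amounts to a 1.7-fold higher number from compound 2 to compound 3 (0.23 log units; within the scatter) and so does not separate the two compounds. Among these compounds, this is the first look at this position, and it shows that a group of two heavy atoms can give way to a whole six-membered aromatic ring with no difference in clearance that stands out from the usual scatter of repeated measurements. It holds for this one pair only, and nothing measured alongside these compounds offers an explanation for the size of this step.

Going by these compounds, an amine, a carboxylic acid or a methoxy group on this same aromatic carbon could still give a number clearly set apart from these, so how much this position matters for clearance in liver cells remains open. On these data alone, it is also open whether pyridin-3-yl in place of cyano would give a similar step on the core of compound 1, which carries a different chain on the ring amine.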